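The compounds below may be only part of what the source reports. "The series", "measured", "known", "first", "only" and "open" are said of these compounds alone.

Of the compounds shown here, three of the shared core have been measured in a functional assay on A549 cells (Homo sapiens) for antiproliferative activity, read by sulforhodamine B assay, with a stated time of 72 h; a higher number here means a weaker inhibitor, a lower number a stronger inhibitor. Compound 1 `COc1ncc(-c2ccc3ncnc(Nc4ccc(OCCO)cc4)c3c2)cc1NS(=O)(=O)c1ccc(F)cc1F` gives 2690 nM. Compound 2 `COc1ncc(-c2ccc3ncnc(Nc4ccc(OCCCO)nc4)c3c2)cc1NS(=O)(=O)c1ccc(F)cc1F` gives 9360 nM, and compound 3 `COc1ncc(-c2ccc3ncnc(Nc4ccc(OCCO)c(F)c4)c3c2)cc1NS(=O)(=O)c1ccc(F)cc1F` gives 6640 nM. Compound 3 thus stands second highest of the three numbers: its step from compound 1 was a 2.5-fold higher number from compound 1 to compound 3 (0.39 log units; beyond the scatter), while the other step reads a 1.4-fold lower number from compound 2 to compound 3 (0.15 log units; within the scatter).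

Compound 4 `COc1ncc(-c2ccc3ncnc(Nc4cnn(CC(=O)O)c4)c3c2)cc1NS(=O)(=O)c1ccc(F)cc1F` differs from compound 3 by 1-(carboxymethyl)-1H-pyrazol-4-yl in place of 3-fluoro-4-(2-hydroxyethoxy)phenyl on a nitrogen on an aromatic ring. Among the compounds with values here, no measured step covers this change directly. The step of a 3.5-fold higher number from compound 1 to compound 2 (0.54 log units; beyond the scatter) is the only one in which the whole group on that nitrogen was exchanged, and it raised the number; the step of a 2.5-fold higher number from compound 1 to compound 3 (0.39 log units; beyond the scatter) also raised it. Both were modest. The exchange here is larger than either, and the two measured exchanges agree in direction, so a rise beyond the scatter is expected for compound 4, with wide uncertainty. The expected step is a 1.8-fold higher number from compound 3 to compound 4 (0.26 log units; within the scatter). For compound 4 in this assay the estimate is 12000 nM, within 3000 nM to 45000 nM.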

Compound 4, half-maximal inhibitory concentration: 5200 nM
Compound 4: the middle estimate sits 2.3-fold (0.36 log units) above what was measured, and the stated range covers the measured number.
By their numbers in this assay, from the lowest: compounds 1, 4, 3 and 2 (each within the scatter of the next, the first and the last beyond it).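

In this assay, within the data shown here, the group on the nitrogen on an aromatic ring could give way to one built on a five-membered aromatic ring with 2 hetero atoms and no step to this new compound left the scatter (first a 1.3-fold lower number from compound 3 to compound 4 (0.11 log units; within the scatter) then a 1.8-fold lower number from compound 2 to compound 4 (0.26 log units; within the scatter) and last a 1.9-fold higher number from compound 1 to compound 4 (0.29 log units; within the scatter)). The only earlier exchange of a whole group at this place (a 3.5-fold higher number from compound 1 to compound 2 (0.54 log units; beyond the scatter)) had gone beyond the scatter, so among these compounds neither the six-membered aromatic ring nor the hydroxy-ended chain is needed for a number in this range. Nothing at hand explains this result.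

The compounds shown leave open what a methyl ester, an amide or a 2-hydroxyethyl chain in place of the carboxymethyl group on the pyrazole would give. They also leave open whether a longer carboxylic acid chain there would read any differently.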